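The compounds below may be only part of what the source reports. "The series", "measured", "known", "first", "only" and "open" are said of these compounds alone.

Measured compounds in a toxicity assay (Homo sapiens) for cytotoxicity, read by MTT assay, with a stated time of 48 h; on this read-out lower numbers stand for stronger inhibition and higher numbers for weaker inhibition:
compound 1 `O=C1C(O)=C(C(c2ccc([N+](=O)[O-])cc2)c2c[nH]c3ccccc23)C(=O)c2ccccc21` — > 200000 nM, a limit of the assay and not a number.
compound 2 `O=C1C(O)=C(C(c2cccc([N+](=O)[O-])c2)c2c[nH]c3ccccc23)C(=O)c2ccccc21` — 91200 nM.
compound 3 `Cc1[nH]c2ccccc2c1C(C1=C(O)C(=O)c2ccccc2C1=O)c1ccc(Cl)cc1` — 40300 nM.

Compound 2 stands at the highest of the two numbers shown in this assay; compound 3 gives the lower number, and the gap between the two lies beyond the scatter. Compound 1 sits at the limit of > 200000 nM in this assay, at which 1 of the 3 values shown sits.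

Within the data shown here, the only step measured within one change is an at least 2.1-fold lower number from compound 1 to compound 2 (0.34 log units; beyond the scatter). It concerns the position of the nitro group on the phenyl ring and does not touch the change now in question.

Compound 4 `COc1ccc(C(C2=C(O)C(=O)c3ccccc3C2=O)c2c[nH]c3ccccc23)cc1Br` differs from compound 2 as follows: 3-bromo-4-methoxyphenyl in place of 3-nitrophenyl on a saturated chain carbon bound to an aromatic carbon and a double-bonded ring carbon. Among the measured compounds shown here, no measured step exchanges a nitrophenyl for a halogen- and methoxy-bearing phenyl. Compound 3, which carries a chlorophenyl together with a further methyl change, gives the lower of the two numbers, but that comparison spans two changes and carries little weight. For compound 4 a modest move toward a lower number is therefore expected, a 1.8-fold lower number from compound 2 to compound 4 (0.26 log units; within the scatter), with wide uncertainty. Compound 4 is estimated at 50000 nM in this assay, in the range 15000 nM to 160000 nM.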

Compound 4, half-maximal inhibitory concentration: 25200 nM
Compound 4: the middle estimate sits 2.0-fold (0.30 log units) above what was measured; low and high end bracket the measured number.
By their numbers in this assay, from the lowest: compounds 4 and 3 (each within the scatter of the next); then compound 2. At a limit, above all of these: compound 1.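

Among these compounds, at the saturated chain carbon bound to an aromatic carbon and a double-bonded ring carbon, the earlier compounds showed only a shift of the nitro group, whereas in this assay 3-bromo-4-methoxyphenyl in place of 3-nitrophenyl gives a 3.6-fold lower number from compound 2 to compound 4 (0.56 log units; beyond the scatter). The same group in place of 4-nitrophenyl gives an at least 7.9-fold lower number from compound 1 to compound 4 (0.89 log units; beyond the scatter), so at this place a ring without a nitro group gives a lower number than both nitrophenyl isomers, beyond the scatter in each case. Compound 1 gives a limit and not a number, so its step reads only as a bound: the limit of > 200000 nM in this assay, at which 1 of the 4 values shown sits.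

Still open, on these data alone, is whether the bromine or the methoxy group carries the step, and how a phenyl bearing an amine or a carboxylic acid would read at this place. Also open, as far as these compounds go, is whether the exchange holds on the core of compound 3 with its methyl group.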